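From Methyl to Bromo: Estimating the Cytotoxicity of Compound 4

This account rests on a few compounds, and the source may have more. Where it says the series, first, only, none or still open, it means among the compounds named here.

Compound 1 `O=C1C(Nc2ccccc2)=CC(=O)c2ncncc21` gives 0.01 ug/mL in a functional assay on HCT-15 cells (Homo sapiens) for cytotoxicity, read by MTT assay, with a stated time of 72 h; on this read-out higher numbers stand for weaker inhibition and lower numbers for stronger inhibition.
Compound 2 `CCOc1ccc(NC2=CC(=O)c3ncncc3C2=O)cc1` gives 0.02 ug/mL in this assay.
Compound 3 `Cc1ccc(NC2=CC(=O)c3ncncc3C2=O)cc1` gives 0.01 ug/mL in this assay.

Compound 3 sits level with compound 1 at the digits shown, the two together the lowest of the three numbers, while compound 2 lies a 2.0-fold lower number from compound 2 to compound 3 (0.30 log units; within the scatter) away; every one of these gaps falls within the scatter. The three compounds share one core and differ only in the group on the outer carbon ring. Compound 4 `O=C1C(Nc2ccc(Br)cc2)=CC(=O)c2ncncc21` carries bromo in place of methyl on an aromatic carbon.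

Going by the values given here, the steps that bear on this change are the ones that swap the same position: a 2.0-fold higher number from compound 1 to compound 2 (0.30 log units; within the scatter) and no change at the digits printed from compound 1 to compound 3 (within the scatter). Neither hydrogen, methyl nor ethoxy at that place moved the number beyond the scatter, so a further swap at the same place is expected to leave this assay essentially unchanged, with no step beyond the scatter in either direction. Compound 4 is therefore expected to show no change at the digits printed from compound 3 to compound 4 (within the scatter), given the flat response seen from compound 3 at 0.01 ug/mL. The estimate for compound 4 is 0.01 ug/mL, with a range from 0.005 ug/mL to 0.03 ug/mL.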

Compound 4, half-maximal inhibitory concentration: 0.01 ug/mL
The estimate for compound 4 equals the measured number at the digits printed; measured number inside the range.
By their numbers in this assay, from the lowest: compounds 1, 3, 4 and 2 (each within the scatter of the next).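

In this assay, the step of no change at the digits printed from compound 3 to compound 4 (within the scatter) is joined by no change at the digits printed from compound 1 to compound 4 (within the scatter) and by a 2.0-fold lower number from compound 2 to compound 4 (0.30 log units; within the scatter) as well, so bromo on this aromatic carbon, para to a large group, behaves like the groups already seen there. The earlier compounds shown here carried only hydrogen, methyl or ethoxy at this place, so the new information is that a bromine atom can take the place of the single carbon atom of methyl with the number staying within the scatter, and the flat response now covers four different groups, none of which can be ranked above another. Nothing available here explains why the number stays so level across these groups.

An amine, a carboxylic acid or a longer chain at this same place could still move the number beyond the scatter, and these four compounds cannot say whether such groups would behave like bromo. From the compounds shown here alone, it also remains open whether a group on another carbon of the same ring would be tolerated as evenly, since all four compounds vary at one place only.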